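This account rests on a few compounds, and the source may have more. Where it says the series, first, only, none or still open, it means among the compounds named here.

Measured so far:

compound 1, `COc1cc(N(C)C)c(NC(=O)c2ccncc2OC)cc1Nc1nccc(-c2cn(C)c3ccccc23)n1`, 3030 nM
compound 2, `COc1cc(N(C)C)c(NC(=O)c2ccncn2)cc1Nc1nccc(-c2cn(C)c3ccccc23)n1`, 5160 nM

Both were tested in a functional assay on A549 cells (Homo sapiens) for antiproliferative activity, read by MTT assay, with a stated time of 72 h; on this read-out higher numbers stand for weaker inhibition and lower numbers for stronger inhibition. Going by the values given here, compound 2 has the higher of the two numbers, and compound 1 sits nearest to it; the one step between them, a 1.7-fold higher number from compound 1 to compound 2 (0.23 log units; within the scatter), changed the group on the carbonyl carbon and stayed within the scatter.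

Compound 3, `COc1cc(N(C)C)c(NC(=O)c2c[nH]cn2)cc1Nc1nccc(-c2cn(C)c3ccccc23)n1`, changes the same position again: 1H-imidazol-4-yl in place of pyrimidin-4-yl on a carbonyl carbon. Among the compounds with values here, the only measured step that bears on this is the one just named, and it was small, so for compound 3 no shift beyond the scatter is expected from this step either. The step from compound 2 to compound 3 is estimated as a 1.0-fold lower number from compound 2 to compound 3 (0.01 log units; within the scatter). For compound 3 the expected value in this assay is therefore 5000 nM, with a range from 2000 nM to 12000 nM.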

Compound 3, half-maximal inhibitory concentration: 3560 nM
The estimate for compound 3 lay 1.4-fold (0.15 log units) above the measured number; measured number inside the range.
By their numbers in this assay, from the lowest: compounds 1, 3 and 2 (each within the scatter of the next).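

In this assay putting the five-membered 1H-imidazol-4-yl in place of the six-membered pyrimidin-4-yl gives a 1.4-fold lower number from compound 2 to compound 3 (0.16 log units; within the scatter) and the comparison with the 3-methoxypyridin-4-yl group gives a 1.2-fold higher number from compound 1 to compound 3 (0.07 log units; within the scatter) so all three groups on this carbonyl carbon read alike. The new point is that this holds even with a different ring size and with 1 hydrogen-bond donor in place of 0, since neither difference separates compound 3 from the other two compounds here. No measurement at hand offers an explanation for this flat result.

Going by these compounds, whether a plain phenyl ring or a non-aromatic group such as a dimethylaminomethyl chain on this carbonyl carbon would move the number beyond the scatter stays open. With all three values this close, the compounds shown cannot tell whether any feature of this ring matters in this assay.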